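A few compounds are considered here, and "the series" means these few. Any claim that something is new, unique, unknown or untested is made for them only; others in the source may bear on it.

Measured so far in a functional assay on MCF7 cells (Homo sapiens) for antiproliferative activity, with a stated time of 96 h; a lower number here means a stronger inhibitor, a higher number a weaker inhibitor:
compound 1 `Cc1cc(=O)oc2cc(OCC(=O)c3ccc(F)cc3)ccc12`: > 100000 nM (a limit)
compound 2 `Cc1cc(=O)oc2cc(OCC(=O)c3ccc(C#N)cc3)ccc12`: > 100000 nM (a limit)

Compound 2 stands only at a limit, > 100000 nM, and has no number in this assay. Compound 1 also stands only at a limit, > 100000 nM. Together they show (the limit of > 100000 nM in this assay, at which 2 of the 2 values shown sit).

The next change leads to compound 3 `Cc1cc(=O)oc2cc(OCC(=O)c3ccc(C(F)(F)F)cc3)ccc12`, with trifluoromethyl in place of cyano on an aromatic carbon, para to a large group: trifluoromethyl in place of cyano on an aromatic carbon. The core and the rest of the molecule stay as in compound 2.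

Going by the values given here, only one measured step bears on this change: a step that the two limits leave unreadable from compound 1 to compound 2. It swaps a group at the same place, but it offers neither a size nor a direction to carry over. With compound 2 at > 100000 nM, the expectation for compound 3 in this assay is that it stays at this limit, with no readable shift in either direction. The expected step is a number no higher from compound 2 to compound 3 (the limit leaves the size open), and it is no more than a nominal figure. For compound 3 the estimated value is 100000 nM, with an expected range of 40000 nM to 200000 nM.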

Compound 3, half-maximal inhibitory concentration: > 100000 nM
Compound 3: no number, only a limit; the forecaster's own chance of this, stated with the estimate: 85%; the middle value lies on the limit itself.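

In this assay no new step can be read from compound 1, compound 2 and compound 3, since each stands only at a limit, which gives neither size nor direction: the limit of > 100000 nM in this assay, at which 3 of the 3 values shown sit.

The compounds shown leave open whether fluoro, cyano or trifluoromethyl on this aromatic carbon differ at all in antiproliferative activity.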